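This account rests on a few compounds, and the source may have more. Where it says the series, first, only, none or still open, it means among the compounds named here.

Measured compounds in an ADME assay on Huh-7 cells (Homo sapiens) for cytotoxicity; a lower number here means a stronger inhibitor of growth, a higher number a weaker inhibitor of growth:
- compound 1 `COc1cc2c(=O)c(C(=O)c3ccc(C)cc3)cn(Cc3ccc(C(F)(F)F)cc3F)c2cc1OC`: > 25000 nM
- compound 2 `COc1cc2c(=O)c(C(=O)OCc3ccccc3C)cn(Cc3ccc(C(F)(F)F)cc3F)c2cc1OC`: 31000 nM
- compound 3 `COc1cc2c(=O)c(C(=O)OCc3cccc(C)c3)cn(Cc3ccc(C(F)(F)F)cc3F)c2cc1OC`: 7300 nM

Compound 1 gives only a limit in this assay, (the limit of > 25000 nM in this assay, at which 1 of the 3 values shown sits), not a number. The two compounds that carry a number are compound 2, with 31000 nM, and compound 3, with 7300 nM; the step of a 4.2-fold lower number from compound 2 to compound 3 (0.63 log units; beyond the scatter) separates them. From compound 1 the step that the limit leaves unreadable from compound 1 to compound 2, and the step of an at least 3.4-fold lower number from compound 1 to compound 3 (0.53 log units; beyond the scatter).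

Compound 4 `COc1cc2c(=O)c(C(=O)c3ccc(C)cc3)cn(Cc3ccc(S(C)(=O)=O)cc3)c2cc1OC` is not yet measured. It differs from compound 1 by 4-(methylsulfonyl)phenyl in place of 2-fluoro-4-(trifluoromethyl)phenyl on a saturated chain carbon bound to an aromatic nitrogen. For the measured compounds named here, all three measured steps concern the group on the carbonyl carbon, and none alters the group on the saturated chain carbon bound to an aromatic nitrogen; no measured step therefore bears directly on the change from compound 1 to compound 4. With compound 1 sitting at the limit, the expectation is that compound 4 stays near that limit, with the step that the limit leaves unreadable from compound 1 to compound 4 expected to lie within the scatter. Compound 4 is estimated at 30000 nM, in the range 12000 nM to 80000 nM, with a fair chance that this assay again reports only a limit.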

Compound 4, concentration for 50% growth inhibition: > 50000 nM
Compound 4 was reported as a limit; the forecaster's own chance of this, stated with the estimate: 60%; at least 1.6-fold (0.22 log units) between middle value and limit.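

Compound 1 and compound 4 both give only limits in this assay, so the step between them cannot be read. The compounds shown leave open how 4-(methylsulfonyl)benzyl compares with 2-fluoro-4-(trifluoromethyl)benzyl on a core where both give a readable number.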